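A few compounds are considered here, and "the series" means these few. Any claim that something is new, unique, unknown or untested is made for them only; others in the source may bear on it.

In a functional assay on MCF7 cells (Homo sapiens) for cytotoxicity, read by colorimetric assay and neutral red uptake, with a stated time of 72 h (a higher number here means a weaker inhibitor, a lower number a stronger inhibitor), two compounds have been measured:

compound 1 `CO[C@@H](C(=O)N[C@H]1CC[C@@H](O)CNC1=O)[C@H](O)[C@@H](O)[C@H](O)/C=C/C(C)(C)C`: 23400 nM
compound 2 `CO[C@@H](C(=O)N[C@@H]1CCCCNC1=O)[C@H](O)[C@@H](O)[C@H](O)/C=C/C(C)(C)C`: 200 nM

Of these two, compound 2 has the lower number and is therefore the stronger inhibitor in this assay. The next compound to be considered is compound 3 `CO[C@@H](C(=O)N[C@H]1CC[C@H](O)CNC1=O)[C@H](O)[C@@H](O)[C@H](O)/C=C/C(C)(C)C`, which is to be compared with compound 2. The change is 6-hydroxy-2-oxoazepan-3-yl in place of 2-oxoazepan-3-yl on an amide-type nitrogen.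

Among the compounds with values here, only one measured step bears on this change: a 120-fold lower number from compound 1 to compound 2 (2.07 log units; beyond the scatter). That large step, beyond the scatter, is the same exchange of groups in the reverse direction. Compound 3 is nevertheless a different structure from compound 1, and a single step cannot show how much the outcome varies between such structures. A large rise in the number is therefore expected in this assay, probably somewhat smaller than the measured step, though with wide uncertainty. The expected change is a 50-fold higher number from compound 2 to compound 3 (1.70 log units; beyond the scatter). For compound 3 the estimated value is 10000 nM, with an expected range of 1500 nM to 50000 nM.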

Compound 3, half-maximal inhibitory concentration: 145000 nM
The estimate for compound 3 lay 15-fold (1.16 log units) below the measured number; measured number above the stated range.
By their numbers in this assay, from the lowest: compound 2; then compound 1; then compound 3.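

In this assay, the exchange now appears in the forward direction on a second structure: a 730-fold higher number from compound 2 to compound 3 (2.86 log units; beyond the scatter). Compound 1 and compound 3 both carry 6-hydroxy-2-oxoazepan-3-yl and both have higher numbers than compound 2, so the large rise on leaving 2-oxoazepan-3-yl is seen with either drawn configuration at the stereocentre that separates them, which one compound alone could not show. The new result also shows that this configuration changes the outcome, since a 6.2-fold higher number from compound 1 to compound 3 (0.79 log units; beyond the scatter) is a modest step but still beyond the scatter, and that step can be tied to a single structural difference: the fact that compounds 1 and 3 differ only in the configuration as drawn.

The compounds shown place only a hydroxy group on the 2-oxoazepan-3-yl ring, so it remains open whether an amine, a methoxy group or a fluorine in its place would raise the number as far, and whether the configuration would matter as it does here. On these data alone, it is also open whether the same gap between the two configurations would appear on a core other than the one shared by these three compounds.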